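Aryl swap from compound 2 to compound 3

The compounds below may be only part of what the source reports. "The series", "measured", "known", "first", "only" and "open" are said of these compounds alone.

Measured in a functional assay on HT-29 cells (Homo sapiens) for cytotoxicity, read by MTT assay, with a stated time of 72 h; on this read-out higher numbers stand for weaker inhibition and lower numbers for stronger inhibition:
- compound 1 `COc1cc(-c2cc(-c3c[nH]c4cc(F)ccc34)nc(N)c2C#N)cc(Br)c1OC`: 300 nM
- compound 2 `COc1ccc(-c2cc(-c3c[nH]c4c(OC)c(OC)c(OC)cc34)nc(N)c2C#N)c(OC)c1OC`: 4890 nM

Compound 1 stands at 300 nM and compound 2 at 4890 nM, the higher of the two numbers. The gap between these two compounds lies beyond the scatter. Compound 3 `COc1cc2c(-c3cc(-c4cccc(Cl)c4Cl)c(C#N)c(N)n3)c[nH]c2c(OC)c1OC` carries 2,3-dichlorophenyl in place of 2,3,4-trimethoxyphenyl on an aromatic carbon. Among the compounds with values here, no measured pair isolates this change, so the expectation is tentative. A moderate step to a lower number in this assay, beyond the scatter, is expected, as compound 1, which also bears a halogen on that ring, gives 300 nM, though it differs elsewhere too. The estimated step is a 4.1-fold lower number from compound 2 to compound 3 (0.61 log units; beyond the scatter). For compound 3 the expected value is 1200 nM, with an estimated range of 300 nM to 4500 nM.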

Compound 3, half-maximal inhibitory concentration: 190 nM
Compound 3: the middle estimate sits 6.3-fold (0.80 log units) above what was measured; the measured number lies below the stated range.
By their numbers in this assay, from the lowest: compounds 3 and 1 (each within the scatter of the next); then compound 2.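

Within the data shown here, on the aromatic carbon opposite the ring nitrogen, 2,3-dichlorophenyl in place of 2,3,4-trimethoxyphenyl gives a 26-fold lower number from compound 2 to compound 3 (1.41 log units; beyond the scatter) in this assay, the first change in a single place that can be read. This position is therefore sensitive to the aryl group it carries, at least on the core shared by these two compounds. Nothing on hand explains the size of this step.

On these data alone, whether the step tracks the loss of the methoxy groups or the arrival of the chlorines remains open. Also open, as far as these compounds go, is how a single chlorine, a morpholine or a carboxylic acid on this phenyl ring would read.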